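From phenyl to 2-chloro-6-fluorophenyl on compound 3

The compounds below may be only part of what the source reports. "The series", "measured", "known", "first", "only" and "open" are said of these compounds alone.

In a functional assay on the whole organism with Rattus norvegicus as the target (a higher number here means that more compound is needed for the effect, a lower number that less compound is needed), compound 1 (`CCOCCOC(=O)C(=O)Nc1nc(-c2cc(Cl)no2)cs1`) gives > 30 mg/kg as a limit of the assay. Compound 2 (`COCCOC(=O)C(=O)Nc1nc(-c2cc(Br)no2)cs1`) likewise gives > 100 mg/kg as a limit. Compound 3 (`CCOCCOC(=O)C(=O)Nc1nc(-c2c(-c3ccccc3)noc2C)cs1`) also gives only a limit, > 100 mg/kg in this assay, so no actual dose is known for it. Compound 4 (`CCOCCOC(=O)C(=O)Nc1nc(-c2c(-c3c(F)cccc3Cl)noc2C)cs1`) carries 2-chloro-6-fluorophenyl in place of phenyl on an aromatic carbon and keeps the rest of compound 3 unchanged. Going by the values given here, no measured step supports a firm prediction, so the size of the change remains uncertain. The expected change is an at least 2.5-fold lower number from compound 3 to compound 4 (0.39 log units; beyond the scatter) toward less compound needed. For compound 4 the estimated dose is 40 mg/kg with an expected range from 5 mg/kg to 200 mg/kg in this assay here.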

Compound 4, dose for half-maximal effect: > 30 mg/kg
Compound 4 gave a limit, no number; the forecaster's own chance of this, stated with the estimate: 55%; the middle value does not contradict the limit.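

In this assay, compound 3 gives > 100 mg/kg, a limit. Compound 4 gives > 30 mg/kg, also a limit, so no step can be read between them. The compounds shown leave open whether 2-chloro-6-fluorophenyl in place of phenyl changes the dose needed.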